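The source may report more compounds than this note shows. Statements on the series, on what has been measured and on what is new or still open speak of the compounds shown alone.

Measured so far in a functional assay on MCF7 cells (Homo sapiens) for inhibition, read by sulforhodamine B assay, with a stated time of 48 h; a lower number here means that less compound is tolerated, a higher number that more compound is tolerated:
- compound 1, `COc1ccc(-c2cc(/C=C/C(=O)c3ccc(OC)c(OC)c3)[nH]n2)cc1`, gives 5110 nM.
- compound 3, `COc1ccc(-c2cc(/C=C/C(=O)c3ccc(N)cc3)[nH]n2)cc1OC`, gives 71200 nM.
- compound 2, `COc1cc(-c2cc(/C=C/C(=O)c3ccc(Cl)c(Cl)c3)[nH]n2)cc(OC)c1OC`, gives > 100000 nM; this is a limit of the assay, not a number.

For the measured compounds named here, compound 2 therefore stands at the top of the range that this assay reports: it sits at the limit of > 100000 nM in this assay, at which 1 of the 3 values shown sits, and of the three measured compounds it is the only one for which no number was obtained. Compound 1 and compound 3 each returned a number, so compound 2 is the least well-defined of the three.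

Compound 4, `COc1cc(-c2cc(/C=C/C(=O)c3ccc(F)c(F)c3)[nH]n2)cc(OC)c1OC`, is not yet measured in this assay. It differs from compound 2 in a single place: 3,4-difluorophenyl in place of 3,4-dichlorophenyl on a carbonyl carbon. Going by the values given here, no pair of measured compounds here differs in just this way, so there is no measured step from which the size of this change can be read off. The closest guide is compound 2 itself, which gives only > 100000 nM and so leaves the starting point unpinned.

With that in mind, the expectation is for no step beyond the scatter, an at least 1.1-fold lower number from compound 2 to compound 4 (0.04 log units; that floor lies within the scatter), and compound 4 is estimated at 90000 nM, within a range of 30000 nM to 300000 nM, with a substantial chance that it too returns only a limit.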

Compound 4, concentration lethal to 50% of the cells: > 100000 nM
Compound 4 ended at the assay's limit; the forecaster's own chance of this, stated with the estimate: 55%; middle value at least 1.1-fold (0.04 log units) from the limit.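

In this assay compound 4 gives > 100000 nM as a limit of the assay, not a number. No step can be read between compound 2 and compound 4, because both stop at the same limit: the limit of > 100000 nM in this assay, at which 2 of the 4 values shown sit.

In this assay the compounds shown leave open how far 3,4-difluorophenyl and 3,4-dichlorophenyl on a carbonyl carbon differ.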